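A Piperidine Ring Replaces a Nitrile Chain

The compounds below may be only part of what the source reports. "The series", "measured", "known", "first", "only" and "open" are said of these compounds alone.

Compound 1 `CC(C)CCn1nc(C(=O)N[C@H]2COc3ccccc3N(C)C2=S)nc1Cc1ccccc1`: 3640 nM
Compound 2 `CN1C(=S)[C@@H](NC(=O)c2nc(Cc3ccccc3)n(CCCCCC#N)n2)COc2ccccc21`: 3830 nM

Both numbers come from a functional assay on HT-29 cells (Homo sapiens) for inhibition, read by luminescence and CellTiter-Glo, with a stated time of 24 h; a higher number here means that more compound is needed for the effect, a lower number that less compound is needed. Compound 1 gives 3640 nM and compound 2 gives 3830 nM; the step between them is a 1.1-fold higher number from compound 1 to compound 2 (0.02 log units; within the scatter), so the two compounds sit within the scatter of one another and the data do not separate compound 2 from compound 1. Compound 3 `CN1C(=S)[C@@H](NC(=O)c2nc(Cc3ccccc3)n(C3CCNCC3)n2)COc2ccccc21` has not yet been measured. It differs from compound 2 in one place: piperidin-4-yl in place of 5-cyanopentyl on an aromatic nitrogen. Going by the values given here, the only measured step bearing on this position, from compound 1 to compound 2, put 3-cyanopropyl in place of isopropyl on a saturated chain carbon and stayed within the scatter, so one change of chain was tolerated there. Among the compounds with values here, no measured step covers putting a ring in place of a chain, so the expectation rests on that tolerance with wide uncertainty. The expected step is a 1.2-fold higher number from compound 2 to compound 3 (0.07 log units; within the scatter). Compound 3 is estimated at 4500 nM, within 1500 nM to 14000 nM.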

Compound 3, half-maximal effective concentration: 1000 nM
The estimate for compound 3 lay 4.5-fold (0.65 log units) above the measured number; the whole stated range lies above it.
By their numbers in this assay, from the lowest: compound 3; then compounds 1 and 2 (each within the scatter of the next).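

In this assay, the aromatic nitrogen of the five-membered ring proves sensitive to what it carries: piperidin-4-yl in place of 5-cyanopentyl gives a 3.8-fold lower number from compound 2 to compound 3 (0.58 log units; beyond the scatter), and piperidin-4-yl in place of isopentyl gives a 3.6-fold lower number from compound 1 to compound 3 (0.56 log units; beyond the scatter). The earlier swap between chains stayed within the scatter, whereas these modest steps show that this position can respond to a change of group, here one that brings a six-membered non-aromatic ring and a hydrogen-bond donor together. No supporting measurement accounts for the lower number.

Going by these compounds, these compounds cannot separate the ring from its nitrogen, so it remains open whether cyclohexyl, with carbon in place of that nitrogen, would match piperidin-4-yl. An open chain ending in an amine, or a piperidine bearing a methyl group on its nitrogen, would also test this.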